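Selenium for amino on the fused core of compound 2

A few compounds are considered here, and "the series" means these few. Any claim that something is new, unique, unknown or untested is made for them only; others in the source may bear on it.

Of the compounds shown here, two have been measured in a functional assay on HTB-54 cells (Homo sapiens) for cytotoxicity, read by MTT assay, with a stated time of 72 h; on this read-out higher numbers stand for weaker inhibition of growth and lower numbers for stronger inhibition of growth. Compound 1 `CSc1nc(NCCCc2ccccc2)c2ccccc2n1` gives 50600 nM. Compound 2 `Nc1nc([SeH])nc2ncccc12` gives 44300 nM, the lower of the two numbers, but the gap to compound 1 lies within the scatter, so the two cannot be ordered on this evidence. Both sit in the weak range.

Compound 3 `[SeH]c1nc([SeH])c2cccnc2n1` is the next compound to be measured. It differs from compound 2 in one place: one selenium atom in place of one nitrogen atom, on an aromatic carbon. Among the measured compounds shown here, no measured pair shows such a change, so its effect is unknown; the expectation rests on compound 2 alone, whose 44300 nM in this assay is taken as the anchor. The expected step is a 1.1-fold lower number from compound 2 to compound 3 (0.04 log units; within the scatter), of a size that would not exceed the scatter in either direction. Compound 3 is therefore estimated at 40000 nM, with a range from 12000 nM to 130000 nM.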

Compound 3, concentration for 50% growth inhibition: 4030 nM
For compound 3 the middle estimate is 9.9-fold (1.00 log units) above the measured one; measured number outside the range, below it.
By their numbers in this assay, from the lowest: compound 3; then compounds 2 and 1 (each within the scatter of the next).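

In this assay, the exchange of amino for selenium on this aromatic carbon, next to the ring nitrogen, gives an 11-fold lower number from compound 2 to compound 3 (1.04 log units; beyond the scatter). Among the compounds shown here, the position is therefore sensitive to this change, which the earlier compounds could not show. Amino is also not needed here for growth inhibition in this pair, and the entering selenium counts no hydrogen-bond donor or acceptor. Nothing available bears on the reason for a step of this size.

The compounds shown leave open whether the step depends on selenium itself or on the departure of amino, a question that a sulfur atom, a hydroxyl or a methylthio group on the same carbon would address. Also open, going by these compounds, is what the selenium shared by compound 2 and compound 3 contributes, which a sulfur atom in its place would test.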